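The compounds below may be only part of what the source reports. "The series", "measured", "known", "first", "only" and "open" are said of these compounds alone.

Measured so far:

Compound 1, `O=C(NCc1ccc(S(=O)(=O)c2ccccc2)cc1)N1Cc2ccncc2C1`: in a physicochemical assay for solubility, in phosphate buffer, with a stated time of 24 h, at pH 7.4, tested at 100 uM (a higher number here means a more soluble compound, a lower number a less soluble compound), compound 1 gives 115000 nM.
Compound 2, `O=C(NCc1ccc(S(=O)(=O)c2cccc(C(F)(F)F)c2)cc1)N1Cc2ccncc2C1`: in this assay compound 2 gives 10000 nM.

Within the data shown here, compound 2 holds the lower of the two numbers, and the only measured step connects it to compound 1: a 12-fold lower number from compound 1 to compound 2 (1.06 log units; beyond the scatter). The two compounds share the same core, and compound 2 differs from compound 1 only in that one change on the aromatic ring attached to the sulfonyl sulfur.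

Compound 3, `O=C(NCc1ccc(S(=O)(=O)c2cc(F)cc(F)c2)cc1)N1Cc2ccncc2C1`, is not yet measured. It differs from compound 2 as follows: 3,5-difluorophenyl in place of 3-(trifluoromethyl)phenyl on a sulfonyl sulfur. Compound 3 therefore sits structurally between compound 1, which carries the unsubstituted phenyl, and compound 2, which carries the trifluoromethyl group; two fluorines now sit on the ring in place of the trifluoromethyl group.

Among the measured compounds shown here, only the step from compound 1 to compound 2 bears on this change, and it was large. Because that step was a 12-fold lower number from compound 1 to compound 2 (1.06 log units; beyond the scatter), and compound 3 gives up the trifluoromethyl group while keeping two fluorines, a rise beyond the scatter is expected for compound 3, though short of the number of compound 1. The expected step from compound 2 to compound 3 is a 3.0-fold higher number from compound 2 to compound 3 (0.48 log units; beyond the scatter). For compound 3 the estimate in this assay is 30000 nM, with a range from 12000 nM to 80000 nM.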

Compound 3, solubility: 16000 nM
Compound 3: middle estimate off by 1.9-fold (0.27 log units), on the high side; low and high end bracket the measured number.
By their numbers in this assay, from the lowest: compounds 2 and 3 (each within the scatter of the next); then compound 1.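

In this assay, putting 3,5-difluorophenyl in place of 3-(trifluoromethyl)phenyl on the sulfonyl sulfur gives a 1.6-fold higher number from compound 2 to compound 3 (0.20 log units; within the scatter) and so leaves compound 2 and compound 3 indistinguishable in this read-out, even though the two groups differ in their substituents and in their heavy-atom count. Measured against the plain phenyl, the same group gives a 7.2-fold lower number from compound 1 to compound 3 (0.86 log units; beyond the scatter) and shows that the large step first seen with trifluoromethyl is not unique to that group: among these three compounds, both substituted rings stand apart from the unsubstituted ring of compound 1, and none goes against this. Nothing shown here offers a measured explanation for this pattern, and the result is therefore only a description of the numbers.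

Both substituted rings carry fluorine, so the compounds shown cannot separate the effect of fluorine from that of simply having any substituent on this ring, and a ring bearing a methoxy group, an amine or a carboxylic acid would address that question. As far as these compounds go, it also remains open whether a single fluorine gives a number closer to that of compound 1 or to those of compound 2 and compound 3.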